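Taking the methyl off compound 1

This account rests on a few compounds, and the source may have more. Where it says the series, first, only, none or still open, it means among the compounds named here.

For the measured compounds named here, in a functional assay on A549 cells (Homo sapiens) for antiproliferative activity, read by sulforhodamine B assay, with a stated time of 48 h (a higher number here means a weaker inhibitor, a lower number a stronger inhibitor), compound 1 (`COc1ccc(C(=O)/C=C\Nc2ccc(-c3nc4cc(OC)c(OC)c(OC)c4s3)cc2C)cc1F`) gives 1690 nM, the lower of the two numbers measured so far. Compound 2 (`COc1cc(OC)c2sc(-c3ccc(N/C=C\C(=O)c4ccc(OC)c(F)c4)c(C)c3)nc2c1`) gives 15300 nM. Going by the values given here, the single measured step, a 9.1-fold higher number from compound 1 to compound 2 (0.96 log units; beyond the scatter), is hydrogen in place of methoxy on an aromatic carbon, and it lies beyond the scatter. Compound 3 (`COc1ccc(C(=O)/C=C\Nc2ccc(-c3nc4cc(OC)c(OC)c(OC)c4s3)cc2)cc1F`) departs from compound 1 at a different place: hydrogen in place of methyl on an aromatic carbon. Among the compounds with values here, no measured step covers this change. The step to compound 2 shows only that one replacement can move the number in this series, and it gives no direction for the loss of the methyl. The expected step is a 1.2-fold higher number from compound 1 to compound 3 (0.07 log units; within the scatter), which is not expected to go beyond the scatter. For compound 3 the estimated value is 2000 nM, with an expected range from 600 nM to 7000 nM.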

Compound 3, half-maximal inhibitory concentration: 15500 nM
Estimate against measurement, compound 3: 7.8-fold (0.89 log units) below; the whole stated range lies below it.
By their numbers in this assay, from the lowest: compound 1; then compounds 2 and 3 (each within the scatter of the next).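

In this assay, the methyl on an aromatic carbon, ortho to a large group and meta to a large group, counts for more than its size of one carbon would suggest: a 9.2-fold higher number from compound 1 to compound 3 (0.96 log units; beyond the scatter). The earlier step showed this only for the replacement of a methoxy group, whereas this one shows that the loss of a single heavy atom, with no hydrogen-bond donor or acceptor among what leaves, can also move the number beyond the scatter. It also gives this position a direction, with the methyl-bearing compound 1 holding the lower number. Nothing measured here accounts for the step.

The compounds shown carry only methyl or hydrogen at this place, so what an ethyl group or a chlorine atom would give there remains open. On these data alone, the step also rests on one pair, and whether it holds with other changes elsewhere in the molecule is unknown.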